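Piperidinol benzyl variation in a hydrolase inhibitor series

The source may report more compounds than this note shows. Statements on the series, on what has been measured and on what is new or still open speak of the compounds shown alone.

The shared core carries a benzyl group on the ring amine nitrogen, and only the aryl part of that benzyl changes. In an assay on Sf21 cells for inhibition of ubiquitin carboxyl-terminal hydrolase 7 (Homo sapiens), read by spectrophotometry, with stated times of 30 min and 2 h (a lower number here means a stronger inhibitor, a higher number a weaker inhibitor), compound 1 `O=c1c2cnn(-c3ccc(F)cc3)c2ncn1CC1(O)CCN(Cc2ccccc2Br)CC1` gives 3100 nM. Compound 2 `N#Cc1ccc(CN2CCC(O)(Cn3cnc4c(cnn4-c4ccc(F)cc4)c3=O)CC2)cc1` is recorded as "not determined" (no result reported) in this assay. Compound 3 `Cc1ccccc1CN1CCC(O)(Cn2cnc3c(cnn3-c3ccc(F)cc3)c2=O)CC1` likewise stands at "not determined" (no result reported) in this assay, so no single number fixes its position, and compound 2 is the other entry without one. Compound 4 `COC(=O)c1ccc(CN2CCC(O)(Cn3cnc4c(cnn4-c4ccc(F)cc4)c3=O)CC2)c(F)c1` differs from compound 3 by 2-fluoro-4-(methoxycarbonyl)phenyl in place of 2-methylphenyl on a saturated chain carbon bound to an amine nitrogen in a ring. For the measured compounds named here, with no measured step from compound 3, no size or direction for the step in this assay can be read from the numbers, and only compound 1 offers any footing. Compound 4 is therefore expected, in this assay, to lie near 3000 nM, within 800 nM to 12000 nM.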

Compound 4, half-maximal inhibitory concentration: 800 nM
Compound 4: middle estimate off by 3.8-fold (0.57 log units), on the high side; low and high end bracket the measured number.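

In this assay, the aryl part of the benzyl group now has one measured step: a 3.9-fold lower number from compound 1 to compound 4 (0.59 log units; beyond the scatter), with 2-fluoro-4-(methoxycarbonyl)phenyl in place of 2-bromophenyl. The steps from compound 2 and compound 3 to compound 4 cannot be read, so the comparison rests on this single pair. Nothing available accounts for the step.

From the compounds shown here alone, the fluorine and the methoxycarbonyl group enter together, so their separate shares in the step remain open. Also open, going by these compounds, is how a carboxylic acid or a primary amide in place of the methyl ester would read.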